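The source may report more compounds than this note shows. Statements on the series, on what has been measured and on what is new or still open speak of the compounds shown alone.

Working notes on the series.

For the measured compounds named here, compound 2 `CCC(CC)Nc1nc(OC)c(-c2ccc(Cl)cc2Cl)nc1OC` gives 8.4 nM in an assay on IMR-32 cells for displacement of a labelled ligand from corticotropin-releasing factor receptor 1 (Homo sapiens), read by scintillation counting, with a stated time of 2 h (on this read-out lower numbers stand for stronger inhibition and higher numbers for weaker inhibition), and this is the lowest of the two numbers so far; the nearest is compound 1 `CCC(CC)Nc1nc(OC)c(-c2ccc(Cl)cc2Cl)nc1C`, which gives 14.4 nM in this assay. The step between them, a 1.7-fold lower number from compound 1 to compound 2 (0.23 log units; within the scatter), comes from a methoxy in place of methyl on an aromatic carbon, and it lies within the scatter, so no order between compound 1 and compound 2 can be drawn from it.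

Compound 3 `CCc1nc(-c2ccc(Cl)cc2Cl)c(OC)nc1NC(CC)CC` is not yet measured. It differs from compound 2 in that (ethyl in place of methoxy on an aromatic carbon). Going by the values given here, the only measured step that bears on this position is a 1.7-fold lower number from compound 1 to compound 2 (0.23 log units; within the scatter), which swapped methyl for methoxy at the same aromatic carbon and stayed within the scatter. Putting ethyl there in place of methoxy is therefore expected to move the number little, with, if anything, a slightly higher number, as an alkyl group replaces the methoxy that accompanied the lowest number seen. For compound 3 the estimate is 12 nM. The expected step for compound 3 is a 1.4-fold higher number from compound 2 to compound 3 (0.15 log units; within the scatter), which is not expected to exceed the scatter.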

Compound 3, inhibition constant: 8 nM
For compound 3 the middle estimate is 1.5-fold (0.18 log units) above the measured one; the range from low to high includes it.
By their numbers in this assay, from the lowest: compounds 3, 2 and 1 (each within the scatter of the next).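

At the aromatic carbon ortho to the (pentan-3-yl)amino group, ethyl in place of methoxy gives a 1.1-fold lower number from compound 2 to compound 3 (0.02 log units; within the scatter) in this assay, so the numbers at this position do not depend on the methoxy oxygen: ethyl has 0 hydrogen-bond acceptors and methoxy has 1, yet the two cannot be told apart. Methyl in place of hydrogen on the chain carbon bound to the ring, which takes the methyl of the earlier compound to ethyl, gives a 1.8-fold lower number from compound 1 to compound 3 (0.26 log units; within the scatter), so methyl, methoxy and ethyl at this carbon now form a set of three with no order among them. The data offer no independent measurement that would account for this flat result.

As far as these compounds go, what stays open is how far the flat range extends at this carbon, since all three groups are small: a longer chain such as butyl, a primary amine or a carboxylic acid could show whether the number moves beyond the scatter. It is also open whether the same holds when the (pentan-3-yl)amino group, the 2,4-dichlorophenyl group or the remaining methoxy is replaced, as all three are shared by the compounds shown.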